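Notes on the substituent on the aromatic nitrogen, compound 4

The source may hold more compounds than are shown below. What is called first, only, known or untested is meant among the compounds shown, and "the series" means these compounds.

In an assay on isolated protein (Oryctolagus cuniculus) with Thromboxane-A synthase (Homo sapiens) as the target, tested at 1 uM (on this read-out higher numbers stand for more inhibition at the one concentration tested (going by the name of the read-out) and lower numbers for less inhibition), compound 2 `O=c1c2ccccc2c(-c2cccnc2)nn1Cc1ccccc1` gives 97%, the highest of the three numbers. Compound 3 `CCOC(=O)CCCn1nc(-c2cccnc2)c2ccccc2c1=O` gives 95%, and compound 1 `Oc1nnc(-c2cccnc2)c2ccccc12` gives 26%. Compound 4 `O=C(O)CCCn1nc(-c2cccnc2)c2ccccc2c1=O` differs from compound 2 by 2-carboxyethyl in place of phenyl on a saturated chain carbon bound to an aromatic nitrogen. Going by the values given here, the only measured step of one change that bears on this is a number 2 percentage points lower from compound 2 to compound 3 (within the scatter), where the phenyl was exchanged for a chain carrying an ethoxycarbonyl; the further change to the carboxy of compound 4 has no measured pair. As that step lay within the scatter, no step beyond the scatter is expected here either, with a wider range downward for the untested acid. Compound 4 is therefore expected to give 88%, within 60% to 98%, meaning an expected step of a number 9 percentage points lower from compound 2 to compound 4 (within the scatter).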

Compound 4, a percentage reported as inhibition, at one concentration (the size of the read-out at that concentration, not a potency): 73%
Compound 4: the middle estimate sits 15 percentage points above what was measured; measured number inside the range.
By their numbers in this assay, from the lowest: compound 1; then compound 4; then compounds 3 and 2 (each within the scatter of the next).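

Unlike the ester chain, the free acid moves the number beyond the scatter, with a number 24 percentage points lower from compound 2 to compound 4 (beyond the scatter) in this assay. The ester alone gives the same picture, with a number 22 percentage points lower from compound 3 to compound 4 (beyond the scatter), so at this place the number depends on whether ethyl or hydrogen sits on the oxygen next to a carbonyl group. No measurement shown gives a cause for this change.

As far as these compounds go, whether a primary amide on the same chain would read like the ester or like the acid remains open. So does whether a longer chain carrying the carboxylic acid would change the size of the step.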